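A few compounds are considered here, and "the series" means these few. Any claim that something is new, unique, unknown or untested is made for them only; others in the source may bear on it.

Of the compounds shown here, two built on the same core have been measured so far. Compound 1, `Cc1nc(N(C)c2ccc([Se]C#N)c(Cl)c2)c2ccccc2n1`, is tested in a functional assay on HCT-116 cells (Homo sapiens) for inhibition, read by MTT assay, with a stated time of 48 h (a lower number here means a stronger inhibitor, a higher number a weaker inhibitor), where compound 1 gives 12 nM. Compound 2, `COc1ccc(N(C)c2nc(C)nc3ccccc23)cc1C(=O)NCC[Se]C#N`, carries a methoxy group on its outer ring together with a longer side chain; in this assay compound 2 gives 313 nM. Of the two numbers, that of compound 2 is the higher, and the gap to compound 1 lies well beyond the usual scatter of repeated measurements, so compound 2 is the weaker inhibitor of the pair.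

Compound 3, `COc1ccc(N(C)c2nc(C)nc3ccccc23)cc1OCCCCCC[Se]C#N`, has not been measured yet. It differs from compound 2 in one place: a group of 10 heavy atoms (7 carbon, 1 nitrogen, 1 oxygen, 1 selenium; no ring) in place of a group of 8 heavy atoms (4 carbon, 2 nitrogen, 1 oxygen, 1 selenium; no ring), on an aromatic carbon The new group sits ortho to the methoxy group and meta to the large group that links the outer ring to the core. For the measured compounds named here, no measured pair shows what such a change does in this assay, so the expectation rests on compound 2 alone. The step of a 1.6-fold lower number from compound 2 to compound 3 (0.19 log units; within the scatter) is expected to be small, toward a lower number, and probably within the scatter. Compound 3 is therefore estimated at 200 nM, with a likely range from 50 nM to 800 nM.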

Compound 3, half-maximal inhibitory concentration: 6180 nM
Compound 3: middle estimate off by 31-fold (1.49 log units), on the low side; measured number outside the range, above it.
By their numbers in this assay, from the lowest: compound 1; then compound 2; then compound 3.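

In this assay, the place on an aromatic carbon, ortho to a methoxy group and meta to a large group, turns out not to tolerate every chain equally: replacing the group of 8 heavy atoms with the group of 10 heavy atoms gives a 20-fold higher number from compound 2 to compound 3 (1.30 log units; beyond the scatter), which makes this a large change. The exchange alters several things at once, since the leaving group has 1 hydrogen-bond donor and 1 double bond, while the entering group has 0 hydrogen-bond donors, no double bond outside aromatic rings and more heavy atoms, and this single step cannot tell which of these differences matters. No measurement is available to explain the size of this step.

From the compounds shown here alone, whether the number depends on chain length alone remains open, as a single pair cannot separate length from the kind of group in the chain, and a shorter or longer chain would be needed to test this. It is equally open how an amine or a carboxylic acid at this place would compare with the two groups shown.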